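Compound 4: a Dimethylaminophenyl Variant of Compound 3

The source may report more compounds than this note shows. Statements on the series, on what has been measured and on what is new or still open speak of the compounds shown alone.

Measured so far:
Compound 1, `O=C(N/N=C/c1ccc(F)cc1)c1cccnc1Nc1cccc(C(F)(F)F)c1`, in a functional assay on the whole organism (strain Wistar) for inhibition, with Rattus norvegicus as the target, read by paw edema, with a stated time of 2 h, at a dose of 10 mg/kg by the intraperitoneal route; a higher number here means more inhibition at the dose given (going by the name of the read-out), a lower number less inhibition: 41.2%
Compound 2, `COc1ccc(/C=N/NC(=O)c2cccnc2Nc2cccc(C(F)(F)F)c2)cc1`, in this assay: 42.4%
Compound 3, `COc1ccc(/C=N/NC(=O)c2cccnc2Nc2cccc(C(F)(F)F)c2)cc1OC`, in this assay: 49%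

Compound 3 holds the highest of the three numbers, but a number 6.6 percentage points higher from compound 2 to compound 3 (within the scatter) and a number 7.8 percentage points higher from compound 1 to compound 3 (within the scatter) both lie within the scatter, so the three compounds cannot be told apart on these data.

Compound 4, `CN(C)c1ccc(/C=N/NC(=O)c2cccnc2Nc2cccc(C(F)(F)F)c2)cc1`, is not yet measured. It differs from compound 3 in one place: 4-(dimethylamino)phenyl in place of 3,4-dimethoxyphenyl on a carbon with a double bond to nitrogen.

The three measured steps all change this same aromatic group: a number 1.2 percentage points higher from compound 1 to compound 2 (within the scatter), a number 6.6 percentage points higher from compound 2 to compound 3 (within the scatter) and a number 7.8 percentage points higher from compound 1 to compound 3 (within the scatter), none of them beyond the scatter. Exchanging one substituted phenyl for another on this carbon has so far left the read-out in this assay unchanged within the noise, and nothing in these data points to a different outcome for 4-(dimethylamino)phenyl.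

Compound 4 is therefore expected to give about 45% in this assay, within 33% to 57%, which means an expected step of a number 4 percentage points lower from compound 3 to compound 4 (within the scatter), not beyond the scatter.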

Compound 4, a percentage reported as inhibition, in the whole organism at one dose (the size of the read-out at that dose, not a potency): 51.4%
Estimate against measurement, compound 4: 6.4 percentage points below; the measured number falls inside the stated range.
By their numbers in this assay, from the lowest: compounds 1, 2, 3 and 4 (each within the scatter of the next, the first and the last beyond it).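

At this position, on the carbon with a double bond to nitrogen, exchanging one aromatic group for another now gives a step beyond the scatter in this assay: a number 10.2 percentage points higher from compound 1 to compound 4 (beyond the scatter) with dimethylamino in place of fluoro, a modest change. The other two new steps, a number 2.4 percentage points higher from compound 3 to compound 4 (within the scatter) and a number 9 percentage points higher from compound 2 to compound 4 (within the scatter) stay within the scatter, so 4-(dimethylamino)phenyl cannot be told apart from 3,4-dimethoxyphenyl or from the group carrying a single methoxy. Within the data shown here, no evidence is available to explain the one step that exceeds the scatter.

On these data alone, it remains open whether a carboxylic acid on this phenyl ring, or a primary amine in place of dimethylamino, would give a similar read-out. The trifluoromethyl group and the shared core are the same in all four compounds, so their contribution cannot be judged.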